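A second fluorine on the amide-bearing ring

The compounds below may be only part of what the source reports. "The series", "measured", "known", "first", "only" and "open" are said of these compounds alone.

Measured compounds in a functional assay on PC-3 cells (Homo sapiens) for cytotoxicity, read by MTT assay, with a stated time of 72 h; a lower number here means a stronger inhibitor, a higher number a weaker inhibitor:
Compound 1 `O=C(Nc1ccc(Oc2ccnc3[nH]ccc23)cc1)c1nn(-c2ccc(Br)cc2)ccc1=O`: 8040 nM
Compound 2 `O=C(Nc1ccc(Oc2ccnc3[nH]ccc23)cc1)c1nn(-c2ccc(Br)cc2F)ccc1=O`: 12800 nM

Compound 2 `O=C(Nc1ccc(Oc2ccnc3[nH]ccc23)cc1)c1nn(-c2ccc(Br)cc2F)ccc1=O` gives the highest of the two numbers in this assay, and its nearest neighbour is compound 1 `O=C(Nc1ccc(Oc2ccnc3[nH]ccc23)cc1)c1nn(-c2ccc(Br)cc2)ccc1=O`, which gives a number that is lower by an amount within the scatter. Compound 3 `O=C(Nc1ccc(Oc2ccnc3[nH]ccc23)c(F)c1)c1nn(-c2ccc(Br)cc2F)ccc1=O` is not yet measured. It differs from compound 2 by fluoro in place of hydrogen on an aromatic carbon, and the fluorine sits on the ring that carries the amide nitrogen. Within the data shown here, only one measured step bears on this change: a 1.6-fold higher number from compound 1 to compound 2 (0.20 log units; within the scatter), which was also a fluoro in place of hydrogen, though on a different ring. That step stayed within the scatter, so there is no ground to expect a movement beyond the scatter in this assay for compound 3 either, and if anything a slightly higher number. Compound 3 is therefore expected to give about 14000 nM, with a plausible range from 5000 nM to 40000 nM, which corresponds to an expected step of a 1.1-fold higher number from compound 2 to compound 3 (0.04 log units; within the scatter).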

Compound 3, half-maximal inhibitory concentration: 8800 nM
Compound 3: the middle estimate sits 1.6-fold (0.20 log units) above what was measured, and the stated range covers the measured number.
By their numbers in this assay, from the lowest: compounds 1, 3 and 2 (each within the scatter of the next).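

In this assay fluoro in place of hydrogen on an aromatic carbon, ortho to a large group and meta to a large group, gives a 1.5-fold lower number from compound 2 to compound 3 (0.16 log units; within the scatter) and so leaves this position without a movement beyond the scatter. This is a second place in the series where the same exchange has been read, and alongside a 1.6-fold higher number from compound 1 to compound 2 (0.20 log units; within the scatter) on a different ring, it shows that among these three compounds neither single fluorine shifts the number beyond the scatter. Nothing shown here offers an independent measurement that could explain the step or say what the added fluorine does at this position.

A single fluorine is a small change, so the compounds shown leave open whether this position would stay as undemanding with a methoxy group, an amine or a carboxylic acid in place of the hydrogen. They also leave open whether replacing the bromine on the other ring, for instance with a nitrile or a morpholine, would move the number beyond the scatter in this cell assay.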